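Nitro for methoxy on the piperazine aryl group

This account rests on a few compounds, and the source may have more. Where it says the series, first, only, none or still open, it means among the compounds named here.

Measured so far:
compound 1, `CN1CCN(CC(=O)Nc2nc3ccccc3[nH]2)CC1`, 54.3%
compound 2, `COc1ccc(N2CCN(CC(=O)Nc3nc4ccccc4[nH]3)CC2)cc1`, 53.2%

In a functional assay, read by spectrophotometry, with a stated time of 30 min, tested at 150 ug/mL (on this read-out lower numbers stand for a weaker effect and higher numbers for a stronger effect at the one concentration tested), compound 1 gives 54.3% and compound 2 gives 53.2%. Among the compounds with values here, the only measured step, a number 1.1 percentage points lower from compound 1 to compound 2 (within the scatter), puts 4-methoxyphenyl in place of methyl on an amine nitrogen in a ring, and the two numbers lie within the scatter of each other, so compound 2 stands on a level with compound 1 rather than apart from it.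

Compound 3, `O=C(CN1CCN(c2ccc([N+](=O)[O-])cc2)CC1)Nc1nc2ccccc2[nH]1`, is not yet measured. Its change from compound 2 is nitro in place of methoxy on an aromatic carbon. Within the data shown here, no measured step swaps one substituent for another on that ring; the step from compound 1 to compound 2 is the nearest reference, and it was within the scatter, so the series so far gives no reason to expect movement. The step is therefore expected to be about a number 1.2 percentage points lower from compound 2 to compound 3 (within the scatter), that is, none beyond the scatter. Compound 3 is expected to give about 52%, with a range from 38% to 66%.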

Compound 3, a percentage reported as activity, at one concentration (the size of the read-out at that concentration, not a potency): 64.9%
Compound 3: the middle estimate sits 12.9 percentage points below what was measured; measured number inside the range.
By their numbers in this assay, from the lowest: compounds 2 and 1 (each within the scatter of the next); then compound 3.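

In this assay, within the data shown here, the aromatic carbon para to a large group is the first place where a change separates two compounds: nitro in place of methoxy gives a number 11.7 percentage points higher from compound 2 to compound 3 (beyond the scatter). Replacing methyl on the amine nitrogen in a ring with 4-nitrophenyl gives a number 10.6 percentage points higher from compound 1 to compound 3 (beyond the scatter), whereas 4-methoxyphenyl in that place gave a number 1.1 percentage points lower from compound 1 to compound 2 (within the scatter), so among these three compounds an aryl group on that nitrogen does not by itself go with a higher number, and the substituent on the aryl group makes the difference. Nothing available bears on what lies behind this step.

With only methoxy and nitro shown on this carbon, it remains open whether the higher number is particular to nitro or would also appear with a nitrile, an amine or a carboxylic acid there. Also open, on these data alone, are how a longer chain in place of methyl on the amine nitrogen would compare, and whether the stronger effect seen at the one concentration in this assay would also appear at other concentrations.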